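Swapping chloro for methoxycarbonyl on the fused ring

The source may report more compounds than this note shows. Statements on the series, on what has been measured and on what is new or still open speak of the compounds shown alone.

Compound 2 `Nc1ccccc1NC(=O)c1ccc(CSC(=S)N2CCc3cc(Cl)ccc32)cc1` gives 31.9% in a functional assay on A-375 cells (Homo sapiens) for antiproliferative activity, read by CCK-8 assay, with a stated time of 72 h, tested at 2 uM; a lower number here means a weaker effect, a higher number a stronger effect of the compound at the concentration tested. Its number is the highest of the three shown, yet the other two lie within the usual scatter of it: compound 3 `Nc1ccccc1NC(=O)c1ccc(CSC(=S)N2CCCC2)cc1` gives 30.2% and compound 1 `Nc1ccccc1NC(=O)c1ccc(CSC(=S)N2CCCc3ccccc32)cc1` gives 26.5%. Compound 4 `COC(=O)c1ccc2c(c1)CCN2C(=S)SCc1ccc(C(=O)Nc2ccccc2N)cc1` differs from compound 2 at one place: methoxycarbonyl in place of chloro on an aromatic carbon. Going by the values given here, no measured step swaps a substituent on the six-membered aromatic ring; the three recorded steps all exchange the whole group on the thiocarbonyl carbon, and each stayed within the scatter: a number 5.4 percentage points higher from compound 1 to compound 2 (within the scatter), a number 3.7 percentage points higher from compound 1 to compound 3 (within the scatter), a number 1.7 percentage points lower from compound 2 to compound 3 (within the scatter). Among the compounds with values here, with no step of this kind available, no shift beyond the scatter is expected, and compound 4 is estimated at 30%, between 17% and 43%. That estimate means an expected step of a number 1.9 percentage points lower from compound 2 to compound 4 (within the scatter).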

Compound 4, a percentage reported as inhibition, at one concentration (the size of the read-out at that concentration, not a potency): 37.5%
The estimate for compound 4 lay 7.5 percentage points below the measured number; measured number inside the range.
By their numbers in this assay, from the lowest: compounds 1, 3, 2 and 4 (each within the scatter of the next, the first and the last beyond it).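

Among the compounds shown, this is the only step that swaps a substituent on the six-membered aromatic ring, and it reads a number 5.6 percentage points higher from compound 2 to compound 4 (within the scatter). The position therefore takes methoxycarbonyl, with four heavy atoms and two hydrogen-bond acceptors, in place of the single chlorine atom, with no shift beyond the scatter. Nothing available explains how either group acts at this position. Still open, going by these compounds, is whether a free carboxylic acid, an amine or a longer ester chain on the same aromatic carbon would move the read-out beyond the scatter.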